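The source may hold more compounds than are shown below. What is called first, only, known or untested is meant among the compounds shown, and "the series" means these compounds.

Measured so far:
- compound 1 `O=C(CCCCOc1no[n+]([O-])c1S(=O)(=O)c1ccccc1)NO` — in a functional assay on cells (Homo sapiens) for inhibition, read by MTT assay, with a stated time of 48 h (a higher number here means a weaker inhibitor, a lower number a stronger inhibitor), compound 1 gives 4300 nM
- compound 2 `O=C(CCCCCCOc1no[n+]([O-])c1S(=O)(=O)c1ccccc1)NO` — in this assay compound 2 gives "not determined" (no result reported)

Compound 2 therefore stands nowhere on the numbers: it carries a longer chain than compound 1 but no half-maximal inhibitory concentration was recorded for it, so nothing can be said of how the two compare. The only anchor for the series is compound 1.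

The next compound, compound 3 `O=C(NO)OCCOCCOc1no[n+]([O-])c1S(=O)(=O)c1ccccc1`, is reached from compound 2 by one change: 2-((hydroxycarbamoyl)oxy)ethoxy in place of 4-(hydroxycarbamoyl)butyl on a saturated chain carbon, two bonds along the chain from an oxygen on an aromatic ring. The chain length is kept; the hydroxamic acid end is replaced by a hydroxycarbamoyl oxy end and an ether oxygen is inserted into the chain, as counted in the difference.

For the measured compounds named here, no step between measured compounds exists for this change, so its size is guessed, not derived. Expectation in this assay: a shift toward weaker inhibition, of a size somewhat beyond the scatter, anchored on compound 1 as the only measured point. For compound 3 the estimated value is 9000 nM, with a range from 2500 nM to 35000 nM.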

Compound 3, half-maximal inhibitory concentration: 19400 nM
Beside the measured number, compound 3's estimate is 2.2-fold (0.33 log units) below it, within the range that was stated.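

In this assay, for the compounds shown here, 2-((hydroxycarbamoyl)oxy)ethoxy in place of 2-(hydroxycarbamoyl)ethyl on a saturated chain carbon, two bonds along the chain from an oxygen on an aromatic ring, gives a 4.5-fold higher number from compound 1 to compound 3 (0.65 log units; beyond the scatter), the first readable step and one toward weaker inhibition. This position therefore tolerates the new chain with a measurable read-out, as compound 3 still gives 19400 nM, while the step from compound 2 cannot be read, with no number recorded for that compound. Nothing at hand bears on the cause of this step.

The compounds shown do not separate the ether oxygen in the chain from the hydroxycarbamoyl oxy end, and the two differences travel together in compound 3, so neither can yet be given its own share of the step. Going by these compounds, how a carboxylic acid or a primary amine at the chain end would read in this assay also remains open, as does any comparison resting on the chain of compound 2.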